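Ring-opened amine in place of piperidine: cytotoxicity outlook

The compounds below may be only part of what the source reports. "The series", "measured", "known", "first", "only" and "open" are said of these compounds alone.

Measured so far:
- Compound 1 `CN1CCN(c2cccn3cc(CN(C)[C@H]4CCCc5cccnc54)nc23)CC1`: in an ADME assay on HOS cells (Homo sapiens) for cytotoxicity (on this read-out higher numbers stand for lower toxicity in this test and lower numbers for higher toxicity in this test), compound 1 gives > 5000 nM, which is a limit of the assay.
- Compound 2 `CN(Cc1cn2c(N3CCC(N)CC3)cccc2n1)[C@H]1CCCc2cccnc21`: in this assay compound 2 gives 6300 nM.
- Compound 3 `CN1CCN(c2cccc3nc(CN(C)[C@H]4CCCc5cccnc54)[nH]c23)CC1`: in this assay compound 3 gives > 5000 nM, which is a limit of the assay.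

Compound 2 is the only one of the three with a number; the other two sit at the limit of > 5000 nM in this assay, at which 2 of the 3 values shown sit. Compound 4 `CNCCN(C)c1cccc2nc(CN(C)[C@H]3CCCc4cccnc43)cn12` differs from compound 2 in one place: methyl(2-(methylamino)ethyl)amino in place of 4-aminopiperidin-1-yl on an aromatic carbon. For the measured compounds named here, no comparable step has been measured, so the expectation rests on compound 2 alone. The change is expected to shift this assay little, if at all beyond the scatter, in either direction. Compound 4 is therefore estimated at 6000 nM, between 2500 nM and 15000 nM, a step from compound 2 to compound 4 of a 1.1-fold lower number from compound 2 to compound 4 (0.02 log units; within the scatter).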

Compound 4, half-maximal cytotoxic concentration: 2200 nM
Estimate against measurement, compound 4: 2.7-fold (0.44 log units) above, outside the stated range (below it).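

In this assay, the aromatic carbon next to the ring nitrogen proves sensitive to the group it carries: methyl(2-(methylamino)ethyl)amino in place of 4-aminopiperidin-1-yl gives a 2.9-fold lower number from compound 2 to compound 4 (0.46 log units; beyond the scatter). The two groups match in hydrogen-bond donors, acceptors and net charge, so those counts do not separate them, while the ring does. This is the only step that can be read, and the other values add no further comparison: the limit of > 5000 nM in this assay, at which 2 of the 4 values shown sit.

The compounds shown leave open whether opening the ring or the methyl groups on the chain accounts for the step. They also leave open how a primary amine at the chain end or a longer chain would read here.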